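From compound 3 to compound 4: limits only

A few compounds are considered here, and "the series" means these few. Any claim that something is new, unique, unknown or untested is made for them only; others in the source may bear on it.

In a functional assay on H292 cells (Homo sapiens) for antiproliferative activity, read by MTT assay, with a stated time of 72 h (a lower number here means a stronger inhibitor, a higher number a weaker inhibitor), compound 3 `CC1(c2cc(-c3ccc(/C=C/C(=O)O)cc3Cl)ccc2O)SCCCS1` gives > 20000 nM, which is a limit and not a number. Compound 1 `CC(C)(C)C#Cc1cc(-c2ccc(/C=C/C(=O)O)cc2Cl)ccc1O` gives > 10000 nM, also a limit. Compound 2 `Cc1cccc(C)c1-c1cc(-c2ccc(/C=C/C(=O)O)cc2Cl)ccc1O` gives > 10000 nM, again a limit. Compound 4 `CCC(CC)(CC)c1cc(-c2ccc(/C=C/C(=O)O)cc2Cl)ccc1O` is not yet measured, and its change is a group of 7 heavy atoms (7 carbon; no ring) in place of a group of 7 heavy atoms (5 carbon, 2 sulfur; one six-membered non-aromatic ring with 2 hetero atoms), on an aromatic carbon, with the 1,1-diethylpropyl group ortho to a hydroxy group. The measured steps at this place bear on it, namely a step that the two limits leave unreadable from compound 1 to compound 3, a step that the two limits leave unreadable from compound 2 to compound 3 and a step that the two limits leave unreadable from compound 1 to compound 2, and none has a readable size. Within the data shown here, no firm step can therefore be foretold in this assay, and another limit is the likeliest result. The estimated move, weakly founded, is an at least 1.6-fold lower number from compound 3 to compound 4 (0.22 log units; that floor lies within the scatter). For compound 4 the estimated half-maximal inhibitory concentration is 12000 nM, with an expected range of 3000 nM to 40000 nM.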

Compound 4, half-maximal inhibitory concentration: > 5000 nM
Compound 4: a limit, no number; the forecaster's own chance of this, stated with the estimate: 75%; the middle value lies beyond the limit too.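

In this assay compound 4 gives only a limit, so its steps from compound 1, compound 2 and compound 3 cannot be read. The compounds shown leave open whether any group at this place yields a measurable number, and how these four compounds rank.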